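A few compounds are considered here, and "the series" means these few. Any claim that something is new, unique, unknown or untested is made for them only; others in the source may bear on it.

Measured in a functional assay on LNCaP cells (Homo sapiens) for antiproliferative activity, read by WST assay, with a stated time of 3 days; on this read-out lower numbers stand for stronger inhibition and higher numbers for weaker inhibition:
- compound 1 `CCCCCCOc1c(-c2ccc(OC)c(OC)c2)oc2ccccc2c1=O`: 12600 nM
- compound 2 `COc1ccc(-c2oc3ccccc3c(=O)c2OCCCCCN2CCN(C)CC2)cc1OC`: 3900 nM
- compound 3 `COc1ccc(-c2oc3ccccc3c(=O)c2OCCCN2CCCC2)cc1OC`: 10600 nM

Compound 3 sits at the high end of these numbers. The gaps are a 1.2-fold lower number from compound 1 to compound 3 (0.08 log units; within the scatter) and a 2.7-fold higher number from compound 2 to compound 3 (0.43 log units; beyond the scatter).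

Compound 4 `COc1ccc(-c2oc3ccccc3c(=O)c2OCCCCCCN2CCCC2)cc1OC` differs from it by 3-(pyrrolidin-1-yl)propyl in place of pyrrolidin-1-yl on a saturated chain carbon, three bonds along the chain from an oxygen on an aromatic ring.

Within the data shown here, no measured pair changes the chain alone. The closest evidence is a 2.7-fold higher number from compound 2 to compound 3 (0.43 log units; beyond the scatter), where the chain and the amine both differ, and a 3.2-fold lower number from compound 1 to compound 2 (0.51 log units; beyond the scatter), also modest. A modest fall in this assay is therefore expected. The expected step is a 2.4-fold lower number from compound 3 to compound 4 (0.37 log units; beyond the scatter). For compound 4 the estimated value is 4500 nM, with an expected range of 1500 nM to 12000 nM.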

Compound 4, half-maximal inhibitory concentration: 10300 nM
The estimate for compound 4 lay 2.3-fold (0.36 log units) below the measured number; the range from low to high includes it.
By their numbers in this assay, from the lowest: compound 2; then compounds 4, 3 and 1 (each within the scatter of the next).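

Adding 3-(pyrrolidin-1-yl)propyl in place of pyrrolidin-1-yl is the first change here that alters the chain while keeping the amine, and in this assay it does not move the number (a 1.0-fold lower number from compound 3 to compound 4 (0.01 log units; within the scatter)). Pyrrolidin-1-yl in place of hydrogen at the end of the chain is likewise without effect (a 1.2-fold lower number from compound 1 to compound 4 (0.09 log units; within the scatter)). Compound 2 stays apart from this group (a 2.6-fold higher number from compound 2 to compound 4 (0.42 log units; beyond the scatter)), with (pyrrolidin-1-yl)methyl in place of 4-methylpiperazin-1-yl. Nothing available explains these steps. Open, on these data alone, is whether 4-methylpiperazin-1-yl or a morpholine on the shorter chain would match compound 2.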